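A few compounds are considered here, and "the series" means these few. Any claim that something is new, unique, unknown or untested is made for them only; others in the source may bear on it.

In a functional assay on HeLa cells (Homo sapiens), read by colorimetric assay, with a stated time of 48 h (a lower number here means a stronger inhibitor, a higher number a weaker inhibitor), the measured compounds are:

Compound 1 `OC[C@@H](O)[C@H]1O[C@@H](n2cnc3c(Cl)nc(Cl)nc32)[C@H](O)[C@@H]1O`: 47100 nM
Compound 2 `Nc1nc(Cl)nc2c1ncn2[C@@H]1O[C@H]([C@H](O)CO)[C@@H](O)[C@H]1O`: > 100000 nM (a limit)
Compound 3 `CNc1nc(Cl)nc2c1ncn2[C@@H]1O[C@H]([C@H](O)CO)[C@@H](O)[C@H]1O`: > 100000 nM (a limit)

Compound 3 gives no true number, since its > 100000 nM is a limit of the assay. It is one of the two compounds at the limit of > 100000 nM in this assay, at which 2 of the 3 values shown sit, and its real value could lie anywhere past that point.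

Compound 4 `CCOc1nc(Cl)nc2c1ncn2[C@@H]1O[C@H]([C@H](O)CO)[C@@H](O)[C@H]1O` has ethoxy in place of methylamino on an aromatic carbon and is otherwise the same as compound 3.

Among the measured compounds shown here, two measured steps concern this same carbon. Amino in place of chloro gave an at least 2.1-fold higher number from compound 1 to compound 2 (0.32 log units; beyond the scatter) and methylamino in place of chloro gave an at least 2.1-fold higher number from compound 1 to compound 3 (0.32 log units; beyond the scatter) so each replacement of chloro weakened the compound beyond the scatter. On these data alone, the true size of both steps stays open. Adding the methyl gave a step that the two limits leave unreadable from compound 2 to compound 3 and so offers no guide. For the measured compounds named here, no measured compound carries ethoxy here, which leaves the forecast loose.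

Since both replacements of chloro measured so far ended at the limit, compound 4 is also expected to be weak, and a number close to the limit seems most likely. The expected move is an at least 1.1-fold lower number from compound 3 to compound 4 (0.07 log units; that floor lies within the scatter) and it may prove unreadable. Compound 4 is estimated at 85000 nM with an expected range of 30000 nM to 200000 nM and the assay may well report only a limit.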

Compound 4, half-maximal inhibitory concentration: > 100000 nM
Compound 4 gave a limit, no number (the forecaster's own chance of this, stated with the estimate: 55%); at least 1.1-fold (0.07 log units) between middle value and limit.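

In this assay, ethoxy joins amino and methylamino as a replacement of chloro on this carbon that weakens the compound, with ethoxy in place of chloro giving an at least 2.1-fold higher number from compound 1 to compound 4 (0.32 log units; beyond the scatter), so the loss seen with the two nitrogen-linked groups also appears with a group linked through oxygen. Compound 4 gives only a limit, > 100000 nM. The steps among compound 2, compound 3 and compound 4 cannot be read, so swapping methylamino, which carries a hydrogen-bond donor, for ethoxy, which carries none, shows no readable effect, and these three compounds cannot be ranked against one another: the limit of > 100000 nM in this assay, at which 3 of the 4 values shown sit.

Among the compounds shown, only chloro on this carbon gives a true number, so it remains open whether any other group here could match or improve on compound 1 at 47100 nM. Also open, on these data alone, is how a bromo or a methyl group on this carbon would read, and whether changing the other chloro group, which all four compounds share, would move the number at all.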